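A Hydroxy-Bearing Ring Replaces 4-Fluorophenyl

The compounds below may be only part of what the source reports. "The series", "measured", "known", "first", "only" and "open" are said of these compounds alone.

In a functional assay on A549 cells (Homo sapiens) for antiproliferative activity, read by MTT assay, with a stated time of 48 h (a lower number here means a stronger inhibitor, a higher number a weaker inhibitor), compound 1 `COc1cc(-c2cccc3nc(-c4ccc(F)cc4)oc23)cc(OC)c1OC` gives 8700 nM. Compound 2 `COc1cc(-c2cccc3nc(-c4cccc(C)c4)oc23)cc(OC)c1OC` gives 16700 nM, and compound 3 `COc1cc(-c2cccc3nc(-c4cccc(O)c4)oc23)cc(OC)c1OC` gives 2000 nM. Thus compound 1 stands close to one neighbour, a 1.9-fold higher number from compound 1 to compound 2 (0.28 log units; within the scatter), and clearly apart from the other, a 4.4-fold lower number from compound 1 to compound 3 (0.64 log units; beyond the scatter).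

Compound 4 `COc1cc(-c2nc3cccc(-c4cc(OC)c(OC)c(OC)c4)c3o2)ccc1O` carries 4-hydroxy-3-methoxyphenyl in place of 4-fluorophenyl on an aromatic carbon. Among the compounds with values here, the nearest guides are two steps that introduce hydroxy: the one above to compound 3 and an 8.4-fold lower number from compound 2 to compound 3 (0.92 log units; beyond the scatter). However, no measured compound carries this exact group, so the guidance is only partial. A somewhat smaller drop in this assay is expected, a 2.9-fold lower number from compound 1 to compound 4 (0.46 log units; beyond the scatter). Compound 4 is estimated at 3000 nM, within an expected range of 900 nM to 9000 nM.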

Compound 4, half-maximal inhibitory concentration: 15700 nM
Beside the measured number, compound 4's estimate is 5.2-fold (0.72 log units) below it; measured number outside the range, above it.
By their numbers in this assay, from the lowest: compound 3; then compounds 1, 4 and 2 (each within the scatter of the next).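

A hydroxy on this ring does not by itself bring the gain seen with compound 3. In this assay the 4-hydroxy-3-methoxyphenyl group stands level with 4-fluorophenyl (a 1.8-fold higher number from compound 1 to compound 4 (0.26 log units; within the scatter)) and with 3-methylphenyl (a 1.1-fold lower number from compound 2 to compound 4 (0.03 log units; within the scatter)), yet sits clearly apart from 3-hydroxyphenyl (a 7.9-fold higher number from compound 3 to compound 4 (0.89 log units; beyond the scatter)). Nothing available explains this gap. Which part of the 4-hydroxy-3-methoxyphenyl group sets it apart from 3-hydroxyphenyl stays open, as does how an amine or a carboxylic acid on this ring would compare.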